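This account rests on a few compounds, and the source may have more. Where it says the series, first, only, none or still open, it means among the compounds named here.

Measured so far:
Compound 1 `O=C(Nc1c(F)cc(F)cc1F)N(Cc1ccc(-c2ccsc2)cc1)C1CCCCCC1`: 23 nM in an assay on microsomes from intestine for inhibition of acyl-CoA:cholesterol acyltransferase (Oryctolagus cuniculus); a higher number here means a weaker inhibitor, a lower number a stronger inhibitor.
Compound 2 `Cc1cc(C)c(NC(=O)N(Cc2ccc(-c3ccsc3)cc2)C2CCCCCC2)c(C)c1`: 19 nM in this assay.
Compound 3 `Cc1cc(C)c(NC(=O)N(Cc2cccc(-c3cnn(C)c3)c2)C2CCCCCC2)c(C)c1`: 44 nM in this assay.

Compound 2 has the lowest number of the three. Compound 1 lies within the scatter of it, so the two cannot be ranked, while compound 3 gives a higher number that lies beyond the scatter. Among the compounds with values here, the only single-point step measured so far, a 1.2-fold lower number from compound 1 to compound 2 (0.08 log units; within the scatter), concerns the ring on the amide-type nitrogen and leaves the biaryl end untouched, so it says nothing direct about the change considered now.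

Compound 4 `Cc1cc(C)c(NC(=O)N(Cc2ccc(-n3ccnc3)cc2)C2CCCCCC2)c(C)c1` has not been measured. Compared with compound 2 the change is 1H-imidazol-1-yl in place of thiophen-3-yl on an aromatic carbon. Within the data shown here, no measured step covers this exchange. The closest hint is compound 3, which also carries a five-membered aromatic ring with two hetero atoms and gives a higher number than compound 2; but compound 3 differs from compound 2 in two places, so it only suggests, rather than shows, that such a ring costs some potency. A modest step toward a higher number is therefore expected, a 2.1-fold higher number from compound 2 to compound 4 (0.32 log units; beyond the scatter). For compound 4 in this assay the estimate is 40 nM, with a range from 12 nM to 130 nM.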

Compound 4, half-maximal inhibitory concentration: 47 nM
The estimate for compound 4 lay 1.2-fold (0.07 log units) below the measured number, and the stated range covers the measured number.
By their numbers in this assay, from the lowest: compounds 2, 1, 3 and 4 (each within the scatter of the next, the first and the last beyond it).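

Within the data shown here, exchanging thiophen-3-yl for 1H-imidazol-1-yl on this aromatic carbon, para to a large group, gives the first direct reading of this position: in this assay there is a 2.5-fold higher number from compound 2 to compound 4 (0.39 log units; beyond the scatter) and this modest step shows that the position is not indifferent to which five-membered aromatic ring it carries. The exchange keeps the ring size and the count of heavy atoms, carries no net charge on either side and adds no hydrogen-bond donor. What differs is the ring's atoms, with sulfur and carbon giving way to nitrogen, and the count of hydrogen-bond acceptors. Nothing measured here explains why the number rises with this exchange.

A single exchange on one background cannot tell whether the same step would appear with the 2,4,6-trifluorophenyl group of compound 1 in place of the 2,4,6-trimethylphenyl group. It also leaves open how a plain phenyl ring, a dimethylamino group or a carboxylic acid on this same carbon would compare with thiophen-3-yl and 1H-imidazol-1-yl.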